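The compounds below may be only part of what the source reports. "The series", "measured", "known", "first", "only" and "open" are said of these compounds alone.

Series notes. Compound 1 `C=CCOC1=CS(=O)(=O)OC1(CC)Cc1ccccc1` and compound 2 `CCC1(Cc2ccccc2)OS(=O)(=O)C=C1OCCc1ccccc1` share one core and differ only in the group on a saturated chain carbon bound to an oxygen on an unsaturated carbon. In an ADME assay on HEL cells (Homo sapiens) for cytotoxicity, with a stated time of 3 days (on this read-out higher numbers stand for lower toxicity in this test and lower numbers for higher toxicity in this test), compound 1 gives 80000 nM. In this assay compound 2 gives >= 20000 nM, which is a limit of the assay and not a number. The step that the limit leaves unreadable from compound 1 to compound 2 cannot be read in size because of the limit of >= 20000 nM in this assay, at which 1 of the 2 values shown sits. Compound 2 therefore stands at the limit only, and whether it differs from compound 1 cannot be told from the numbers shown.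

Compound 3 `CCC1(Cc2ccccc2)OS(=O)(=O)C=C1OCc1ccc(C)cc1` is not yet measured in this assay. Its difference from compound 2: 4-methylphenyl in place of benzyl on a saturated chain carbon bound to an oxygen on an unsaturated carbon. Among the measured compounds shown here, no measured step bears directly on this change; the only step recorded, from compound 1 to compound 2, is unreadable, so the reference for compound 3 is the limit of compound 2 together with the value of compound 1. For compound 3 the step that the limit leaves unreadable from compound 2 to compound 3 is expected to stay within the scatter. For compound 3 the estimated value in this assay is 40000 nM, expected between 15000 nM and 100000 nM, with a fair chance that again only a limit is reported.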

Compound 3, minimum cytotoxic concentration: >= 16000 nM
Compound 3: only a limit was reported; the forecaster's own chance of this, stated with the estimate: 50%; the middle value does not contradict the limit.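

In this assay compound 3 gives >= 16000 nM, a limit of the assay and not a number. Among the compounds shown here, no step from compound 3 to compound 1 or compound 2 can be read from this. The compounds shown leave open whether 4-methylphenyl in place of benzyl changes the minimum cytotoxic concentration, and where compound 2 and compound 3 stand relative to compound 1.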